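The source may hold more compounds than are shown below. What is called first, only, known or untested is meant among the compounds shown, and "the series" means these compounds.

For the measured compounds named here, in a functional assay on A549 cells (Homo sapiens) for cytotoxicity, read by sulforhodamine B assay, with a stated time of 3 days (on this read-out higher numbers stand for an effect only at larger amounts of compound and lower numbers for an effect already at smaller amounts), compound 1 `COC(=O)c1c(C)coc1-c1ccc2c(c1OC)CCCC2(C)C` gives 61 uM, the higher of the two numbers measured so far. Compound 2 `Cc1coc(-c2ccc3c(c2O)CCCC3(C)C)c1CO` gives 24.5 uM, a gap beyond the usual scatter. Compound 3 `COCc1c(C)coc1-c1ccc2c(c1OC)CCCC2(C)C` has not yet been measured. It carries methoxymethyl in place of methoxycarbonyl on an aromatic carbon. Going by the values given here, no measured pair isolates this change, so only a slight shift toward a lower number in this assay is expected, and none beyond the scatter. The expected step is a 1.5-fold lower number from compound 1 to compound 3 (0.16 log units; within the scatter). For compound 3 the estimated value is 42 uM, with an expected range of 18 uM to 95 uM.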

Compound 3, concentration for half-maximal effect: 19.4 uM
Compound 3: the middle estimate sits 2.2-fold (0.34 log units) above what was measured; the range from low to high includes it.
By their numbers in this assay, from the lowest: compounds 3 and 2 (each within the scatter of the next); then compound 1.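

In this assay the swap of methoxycarbonyl for methoxymethyl on this aromatic carbon gives a 3.1-fold lower number from compound 1 to compound 3 (0.50 log units; beyond the scatter) and so lies beyond the scatter. For the compounds shown here, this is the first step here that isolates a single place, and it shows that this position, two ring bonds from the ring oxygen, responds to the change. Nothing available on the compounds accounts for the shift.

The compounds shown leave open how an amine or a carboxylic acid at this position would read, and whether the same step would hold on a different core.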